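The source may hold more compounds than are shown below. What is called first, only, known or untested is meant among the compounds shown, and "the series" means these compounds.

Compound 1 `O=C1Nc2ccccc2/C1=C/c1ccc(-c2cn(-c3cccc(F)c3)nn2)cc1`: > 20000 nM
Compound 2 `Cc1ccc(-n2cc(-c3ccc(/C=C4\C(=O)Nc5ccc(F)cc54)cc3)nn2)cc1`: 3980 nM

Both compounds were tested in a functional assay on HT-29 cells (Homo sapiens) for inhibition, read by CCK-8 assay, with a stated time of 24 h; a lower number here means a stronger inhibitor, a higher number a weaker inhibitor. The entry for compound 1, > 20000 nM, is a limit of the assay and not a number. Among the measured compounds shown here, that makes compound 2, at 3980 nM, the only compound with a measured number, so it is the sole numerical reference point here.

The next compound, compound 3 `N#Cc1cccc(-n2cc(-c3ccc(/C=C4\C(=O)Nc5ccc(F)cc54)cc3)nn2)c1`, differs from compound 2 in one place: 3-cyanophenyl stands in place of 4-methylphenyl on an aromatic nitrogen of a five-membered aromatic ring with 3 nitrogen (3-cyanophenyl in place of 4-methylphenyl on an aromatic nitrogen). For the measured compounds named here, no measured pair in this small set isolates a change of this kind, so the expectation is a cautious one. In this assay, the estimated step of a 1.5-fold higher number from compound 2 to compound 3 (0.18 log units; within the scatter) is expected to stay small, within the usual scatter, with a slight lean towards a weaker inhibitor. A wide range is kept, and a result that reaches the limit of the assay cannot be ruled out. Compound 3 is expected at about 6000 nM, with an estimated range of 1800 nM to 20000 nM.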

Compound 3, half-maximal inhibitory concentration: > 20000 nM
Compound 3: only a limit was reported; the forecaster's own chance of this, stated with the estimate: 20%; at least 3.3-fold (0.52 log units) between middle value and limit.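

The earlier compounds shown here gave no pair that isolated a single change, and this one does: in this assay, placing 3-cyanophenyl in place of 4-methylphenyl on an aromatic nitrogen gives an at least 5.0-fold higher number from compound 2 to compound 3 (0.70 log units; beyond the scatter), so the group at this position clearly affects the result. Compound 3 gives > 20000 nM, which is a limit of the assay and not a number. The step therefore has a lower bound but no known size, and the true gap could be much larger than the printed one: the limit of > 20000 nM in this assay, at which 2 of the 3 values shown sit.

This swap changes both the group on the phenyl ring and where that group sits, so the pair cannot tell whether the nitrile itself or its new place on the ring accounts for the loss. Also open, on these data alone, is whether a different group on the same phenyl ring, such as an amine, a carboxylic acid or a longer chain, would keep a measured number or improve on compound 2.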